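Notes on a three-compound hydroxyphenyl series

The compounds below may be only part of what the source reports. "The series", "measured", "known", "first", "only" and "open" are said of these compounds alone.

Compound 1 `Oc1cccc(-c2cc(-c3cccs3)cc(-c3ccccc3O)n2)c1` gives 1.5% in an assay on isolated protein for inhibition of DNA topoisomerase 1 (Homo sapiens), with a stated time of 30 min, tested at 20 uM; on this read-out higher numbers stand for a stronger effect at the one concentration tested and lower numbers for a weaker effect. Compound 2 `Oc1ccccc1-c1cc(-c2ccco2)cc(-c2ccccc2O)n1` gives 0.2% in this assay, the lower of the two numbers shown, though its gap to compound 1 lies within the scatter. Compound 3 `Oc1cccc(-c2cc(-c3ccco3)cc(-c3ccccc3O)n2)c1` is not yet measured; it differs from compound 2 by 3-hydroxyphenyl in place of 2-hydroxyphenyl on an aromatic carbon. For the measured compounds named here, no step between measured compounds exists in this set, so the size of the change in this assay cannot be read off. Given that compound 1 shows 1.5% while carrying a 3-hydroxyphenyl group, no step beyond the scatter is expected, a number 0.8 percentage points higher from compound 2 to compound 3 (within the scatter). Compound 3 is estimated at 1%, between 0% and 8%.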

Compound 3, a percentage reported as inhibition, at one concentration (the size of the read-out at that concentration, not a potency): 0%
Beside the measured number, compound 3's estimate is 1 percentage points above it; measured number inside the range.
By their numbers in this assay, from the lowest: compounds 3, 2 and 1 (each within the scatter of the next).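

In this assay 3-hydroxyphenyl in place of 2-hydroxyphenyl next to the ring nitrogen gives a number 0.2 percentage points lower from compound 2 to compound 3 (within the scatter) and so does not separate the two hydroxyphenyl groups at this position when furan-2-yl is present. Furan-2-yl in place of thiophen-2-yl gives a number 1.5 percentage points lower from compound 1 to compound 3 (within the scatter) and does not separate those two rings either, with 3-hydroxyphenyl present. No supporting data bear on these results.

Open, going by these compounds, is whether any change at this position moves the number beyond the scatter. On these data alone, an aminophenyl or carboxyphenyl group there would test this, and the same exchange with thiophen-2-yl in place of furan-2-yl also remains open.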